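Trimming the Amino Side Chain on the Shared Core

The source may report more compounds than this note shows. Statements on the series, on what has been measured and on what is new or still open speak of the compounds shown alone.

Measured so far:
Compound 1, `CCCNc1nnc(SCC(=O)N(Cc2cccc([N+](=O)[O-])c2)c2ccc(F)cc2)s1`: 45.2%
Compound 2, `CC(C)CNc1nnc(SCC(=O)N(Cc2cccc([N+](=O)[O-])c2)c2ccc(F)cc2)s1`: 31.8%
Compound 3, `C=CCNc1nnc(SCC(=O)N(Cc2cccc([N+](=O)[O-])c2)c2ccc(F)cc2)s1`: 43.2%

Three compounds share one core and differ only in the chain attached to the nitrogen on the aromatic ring. In an assay on isolated protein for inhibition of Amine oxidase [flavin-containing] A (Homo sapiens), read by fluorescence and Amplex Red, with a stated time of 30 min, tested at 0.1 uM (a higher number here means a stronger effect of the compound at the concentration tested, a lower number a weaker effect), compound 3 gives 43.2%, the second highest of the three numbers; its nearest neighbour is compound 1, where a number 2 percentage points lower from compound 1 to compound 3 (within the scatter), and its furthest is compound 2, where a number 11.4 percentage points higher from compound 2 to compound 3 (beyond the scatter).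

Compound 4, `CCNc1nnc(SCC(=O)N(Cc2cccc([N+](=O)[O-])c2)c2ccc(F)cc2)s1`, has not been measured. Relative to compound 3 the change is methyl in place of vinyl on a saturated chain carbon bound to a nitrogen on an aromatic ring, which shortens the allylamino group to an ethylamino group.

For the measured compounds named here, two measured steps touch this place. The step of a number 2 percentage points lower from compound 1 to compound 3 (within the scatter) shows that swapping vinyl for ethyl here changes little, while a number 11.4 percentage points higher from compound 2 to compound 3 (beyond the scatter) shows a modest gain when a branched isopropyl is replaced by vinyl. Going by the values given here, neither step removes a carbon outright, so the shortening in compound 4 has no direct precedent. Given that the exchange in compound 1 and compound 3 stayed within the scatter, no step beyond the scatter is expected for a number 1.2 percentage points lower from compound 3 to compound 4 (within the scatter).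

Compound 4 is therefore estimated to give 42%, with a range from 28% to 56%.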

Compound 4, a percentage reported as inhibition, at one concentration (the size of the read-out at that concentration, not a potency): 42.1%
Compound 4: the middle estimate sits 0.1 percentage points below what was measured; measured number inside the range.
By their numbers in this assay, from the lowest: compound 2; then compounds 4, 3 and 1 (each within the scatter of the next).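

For the compounds shown here, removing a carbon outright from the chain, the one kind of change the earlier steps lacked, barely registers in this assay: allylamino to ethylamino gives a number 1.1 percentage points lower from compound 3 to compound 4 (within the scatter) and trimming the end methyl of the propyl chain gives a number 3.1 percentage points lower from compound 1 to compound 4 (within the scatter). The three unbranched chains therefore cannot be told apart here, whether they differ in length or in carrying a double bond, while the branched chain of compound 2 stands apart, with a number 10.3 percentage points higher from compound 2 to compound 4 (beyond the scatter) adding a third compound that lies beyond the scatter from it. No independent measurement is available to explain why the branched chain gives the lowest number of the four.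

Still open, on these data alone, is how far this tolerance extends, whether a methylamino group or a free amine on the shared core would hold the same level at the short end, and whether a longer chain such as butyl would do so at the other. With only one branched chain shown, it also remains open whether branching itself separates compound 2 from the rest, which a secondary butyl or cyclopropylmethyl chain could help to test.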